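Swapping a Para Group on the Urea Aryl Ring

The source may report more compounds than this note shows. Statements on the series, on what has been measured and on what is new or still open speak of the compounds shown alone.

Measured so far:
- compound 1, `CCOc1ccc(NC(=O)Nc2cccc(CNc3nccnc3Cl)c2)cc1`: 7050 nM
- compound 2, `O=C(Nc1cccc(CNc2nccnc2Cl)c1)NC1CCCC1`: 18400 nM
- compound 3, `O=C(Nc1cccc(CNc2nccnc2Cl)c1)Nc1ccc(F)c(Cl)c1`: 6750 nM

All three share a core that carries a urea, and they differ only in the group attached to the far nitrogen of that urea. In a functional assay on HepG2 cells (Homo sapiens) for antiproliferative activity, read by MTT assay, with a stated time of 48 h (a lower number here means a stronger inhibitor, a higher number a weaker inhibitor), compound 1 stands second highest of the three numbers; its nearest neighbour is compound 3, with a 1.0-fold lower number from compound 1 to compound 3 (0.02 log units; within the scatter), while compound 2 lies furthest, with a 2.6-fold higher number from compound 1 to compound 2 (0.42 log units; beyond the scatter).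

Compound 4, `CS(=O)(=O)c1ccc(NC(=O)Nc2cccc(CNc3nccnc3Cl)c2)cc1`, keeps the aryl ring of compound 1 and changes one substituent on it: methylsulfonyl in place of ethoxy on an aromatic carbon. Going by the values given here, of the measured steps, the one from compound 1 to compound 3 bears most directly on this, since it also exchanges a substituent on an aryl ring and produced no step beyond the scatter. Among the compounds with values here, the only step beyond the scatter, from compound 2 to compound 3 (a 2.7-fold lower number from compound 2 to compound 3 (0.44 log units; beyond the scatter)), involves replacing a cyclopentyl with an aryl ring, which is not the kind of change made here. No step beyond the scatter is therefore expected in this assay, and compound 4 is estimated at 7000 nM, with a range from 3000 nM to 17000 nM, which means an expected step of a 1.0-fold lower number from compound 1 to compound 4 (0.00 log units; within the scatter).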

Compound 4, half-maximal inhibitory concentration: 15100 nM
Beside the measured number, compound 4's estimate is 2.2-fold (0.33 log units) below it; the range from low to high includes it.
By their numbers in this assay, from the lowest: compounds 3 and 1 (each within the scatter of the next); then compounds 4 and 2 (each within the scatter of the next).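

In this assay, placing methylsulfonyl in place of ethoxy on an aromatic carbon para to a large group gives a 2.1-fold higher number from compound 1 to compound 4 (0.33 log units; beyond the scatter) and so shows that one substituent on this aryl ring can, on its own, shift the number beyond the scatter. The earlier exchange of one aryl pattern for another gave only a 1.0-fold lower number from compound 1 to compound 3 (0.02 log units; within the scatter) and hinted at a tolerant ring, but the new step, though modest, shows that this tolerance does not extend to every substituent. Nothing available accounts for the shift, and the data offer no measured property of either group.

The compounds shown leave open how an amine, a carboxylic acid or a longer chain such as butoxy would fare at this same position. Two groups at one position give a single step and do not yet define a trend.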